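The compounds below may be only part of what the source reports. "The series", "measured", "known", "first", "only" and "open" are said of these compounds alone.

Three compounds of this series have been examined in an ADME assay on MT4 cells (Homo sapiens) for activation, read by MTT assay; on this read-out lower numbers stand for higher toxicity in this test and higher numbers for lower toxicity in this test. Compound 1 `CCCCSc1nc(C(C)c2c(F)cccc2F)c(CC)c(=O)[nH]1` gives > 3000 nM in this assay, a limit of the assay rather than a number. Compound 2 `CCc1c(C(C)c2c(F)cccc2F)nc(SC2CCCC2)[nH]c1=O` gives > 3000 nM in this assay, also a limit. Compound 3 `CCCCSc1nc(C(CC)c2c(F)cccc2F)c(C)c(=O)[nH]1` gives > 3000 nM in this assay, again a limit. Compound 2 differs from compound 1 by cyclopentyl in place of butyl on a sulfur. The resulting step that the two limits leave unreadable from compound 1 to compound 2 cannot be read because of the limit of > 3000 nM in this assay, at which 3 of the 3 values shown sit. Compound 3 shares its atoms with compound 1 but joins them differently; the difference between the two cores is not broken down here. Compound 4 `CCC(c1nc(SC2CCCC2)[nH]c(=O)c1C)c1c(F)cccc1F`, not yet measured, differs from compound 3 by the same change, (cyclopentyl in place of butyl on a sulfur). Beside the earlier unreadable step, the step is expected to be a step that the limit leaves unreadable from compound 3 to compound 4, an expectation resting on (the limit of > 3000 nM in this assay, at which 3 of the 3 values shown sit). Compound 4 is therefore expected to give 6000 nM in this assay, between 3000 nM and 30000 nM.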

Compound 4, half-maximal cytotoxic concentration: 30000 nM
Compound 4: the middle estimate sits 5.0-fold (0.70 log units) below what was measured; the range from low to high includes it.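

No step can be read between compound 3 and compound 4. Compound 3 gives > 3000 nM, a limit of the assay and not a number. The compounds shown leave open how far cyclopentyl in place of butyl on a sulfur shifts the value in this assay.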